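Chloro Removal on Two Isatin Cores and a Predicted Fourth Compound

The source may hold more compounds than are shown below. What is called first, only, known or untested is meant among the compounds shown, and "the series" means these compounds.

Measured compounds:
compound 1, `O=C1C(=O)N(CN(c2ccccc2)c2ccccc2)c2cccc(Cl)c21`: 14400 nM
compound 2, `O=C1C(=O)N(CN(c2ccccc2)c2ccccc2)c2ccccc21`: 21500 nM
compound 3, `Cc1ccc2nc(/N=C3\C(=O)N(CN(c4ccccc4)c4ccccc4)c4cccc(Cl)c43)sc2c1`: 85000 nM

In a functional assay on MDA-MB-468 cells (Homo sapiens) for cytotoxicity, read by sulforhodamine B assay, with a stated time of 48 h (a lower number here means a stronger inhibitor of growth, a higher number a weaker inhibitor of growth), compound 1 gives 14400 nM. The change from compound 1 to compound 2 is hydrogen in place of chloro on an aromatic carbon. In this assay compound 2 gives 21500 nM, so the step of a 1.5-fold higher number from compound 1 to compound 2 (0.17 log units; within the scatter) does not separate the two compounds. Compound 3 gives 85000 nM in this assay, the highest of the three numbers; its core differs from that of compound 1 in a way that is not broken down here.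

Compound 4, `Cc1ccc2nc(/N=C3\C(=O)N(CN(c4ccccc4)c4ccccc4)c4ccccc43)sc2c1`, has not yet been measured in this assay. Among the measured compounds shown here, it stands to compound 3 as compound 2 stands to compound 1: the change is hydrogen in place of chloro on an aromatic carbon, the same change that was made from compound 1 to compound 2, and it is the only kind of single change seen in this set. Because the earlier step of a 1.5-fold higher number from compound 1 to compound 2 (0.17 log units; within the scatter) stayed within the scatter, the expected step of a 1.3-fold higher number from compound 3 to compound 4 (0.11 log units; within the scatter) is of the same small size. On that basis compound 4 is expected to give about 110000 nM in this assay, within a range from 50000 nM to 250000 nM, the uncertainty coming from compound 3 being measured only once at 85000 nM.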

Compound 4, concentration for 50% growth inhibition: 17700 nM
The estimate for compound 4 lay 6.2-fold (0.79 log units) above the measured number, outside the stated range (below it).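

In this assay, among the compounds shown here, hydrogen in place of chloro on an aromatic carbon gives a 4.8-fold lower number from compound 3 to compound 4 (0.68 log units; beyond the scatter), so on the core of compound 3 the chloro-bearing member is the one with the higher number, and the loss of that single atom separates the two compounds. Set beside the earlier pair, the same change does not give the same result on the two cores: the same change on two cores in this assay, a 1.5-fold higher number (0.17 log units; within the scatter) from compound 1 to compound 2 and a 4.8-fold lower number (0.68 log units; beyond the scatter) from compound 3 to compound 4, 7.2-fold (0.86 log units) apart, beyond the scatter of two such steps. This shows that, in this series and in this assay, the size of the step seen on the core of compound 1 could not be carried over to the core of compound 3, but it does not show why the two cores part ways, and two pairs cannot tell how the change would behave on any further core.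

The compounds shown leave open whether a bromo group, a methoxy group or an amine on that same aromatic carbon would follow the pattern of the core of compound 1 or that of the core of compound 3. They also leave open how the chloro step would read if the methyl group of compound 3 gave way to a carboxylic acid or a longer chain.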